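This account rests on a few compounds, and the source may have more. Where it says the series, first, only, none or still open, it means among the compounds named here.

Two compounds share one core and differ only in the group on the chain carbon bound to the carbonyl carbon. Compound 1 `Cn1c(-c2ccc(NC(=O)CSC3=NCCS3)cc2)nc(-c2ccccc2)c1-c1ccccc1` gives 41.8% in a functional assay on MCF7 cells (Homo sapiens) for cytotoxicity, read by MTT assay, with a stated time of 24 h, tested at 16 ug/mL (on this read-out lower numbers stand for a weaker effect and higher numbers for a stronger effect at the one concentration tested), and compound 2 `CCN1CCN(CC(=O)Nc2ccc(-c3nc(-c4ccccc4)c(-c4ccccc4)n3C)cc2)CC1` gives 32.8% in this assay. Of these two numbers compound 2 stands lowest, yet the step of a number 9 percentage points lower from compound 1 to compound 2 (within the scatter) lies within the scatter, so the two compounds cannot be told apart on this read-out. Compound 3 `Cn1c(-c2ccc(NC(=O)CN3CCN(c4ccccc4)CC3)cc2)nc(-c2ccccc2)c1-c1ccccc1` keeps everything in compound 2 except one change: phenyl in place of ethyl on an amine nitrogen in a ring. Among the compounds with values here, no measured step touches the group on this ring nitrogen; the only step known, a number 9 percentage points lower from compound 1 to compound 2 (within the scatter), exchanged a whole ring for another and still stayed within the scatter. The step of a number 2.2 percentage points higher from compound 2 to compound 3 (within the scatter) is therefore expected to be no larger than the scatter. Compound 3 is estimated at 35% in this assay, within a range from 20% to 50%.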

Compound 3, a percentage reported as activity, at one concentration (the size of the read-out at that concentration, not a potency): 59.6%
Beside the measured number, compound 3's estimate is 24.6 percentage points below it; the measured number lies above the stated range.
By their numbers in this assay, from the lowest: compounds 2 and 1 (each within the scatter of the next); then compound 3.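

In this assay, the group on this ring nitrogen clearly matters: phenyl in place of ethyl gives a number 26.8 percentage points higher from compound 2 to compound 3 (beyond the scatter), the only step at this position shown here. The change also separates compound 3 from the differently built group of compound 1, with a number 17.8 percentage points higher from compound 1 to compound 3 (beyond the scatter), whereas compound 2 could not be told apart from compound 1. Nothing available explains why this exchange raises the number.

On these data alone, it remains open whether the aromatic ring itself counts or whether other groups on this nitrogen, such as benzyl, cyclohexyl or a phenyl ring carrying a chlorine atom or a methoxy group, would do the same. With a single tested concentration, the read-out also leaves the potency of these compounds open.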